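A few compounds are considered here, and "the series" means these few. Any claim that something is new, unique, unknown or untested is made for them only; others in the source may bear on it.

Compound 1 `c1ccc(-c2ccc(-c3ccc(-c4nc5ccccc5[nH]4)cc3)cc2)cc1` gives 100000 nM in a functional assay on SiHa cells (Homo sapiens) for inhibition, read by sulforhodamine B assay; on this read-out higher numbers stand for weaker inhibition of growth and lower numbers for stronger inhibition of growth. Compound 2 `COc1ccc(-c2ccc(-c3ccc(-c4nc5ccccc5[nH]4)cc3)cc2)cc1` carries one extra group, (methoxy in place of hydrogen on an aromatic carbon), and in this assay compound 2 gives 2760 nM; that single change made a 36-fold lower number from compound 1 to compound 2 (1.56 log units; beyond the scatter). Compound 3 `COc1ccc(-c2ccc(-c3ccc(-c4nc5c(O)cccc5[nH]4)cc3)cc2)cc1OC` differs from compound 1 in more than one place, so the difference between the two cores is not broken down here; in this assay compound 3 gives 1110 nM. Compound 4 `COc1cc(-c2ccc(-c3ccc(-c4nc5c(O)cccc5[nH]4)cc3)cc2)cc(OC)c1OC` awaits measurement. It differs from compound 3 by methoxy in place of hydrogen on an aromatic carbon, the same kind of change as from compound 1 to compound 2, though the new group now sits ortho to a methoxy group and meta to a methoxy group rather than para to a large group alone. Because the earlier step of a 36-fold lower number from compound 1 to compound 2 (1.56 log units; beyond the scatter) was large, yet compound 3 already carries methoxy groups, a smaller step is expected, a 1.9-fold lower number from compound 3 to compound 4 (0.27 log units; within the scatter). Compound 4 is therefore estimated at 600 nM, probably between 200 nM and 2000 nM.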

Compound 4, concentration for 50% growth inhibition: 170 nM
For compound 4 the middle estimate is 3.5-fold (0.55 log units) above the measured one; measured number outside the range, below it.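

Adding a methoxy group lowers the number again in this assay, with a 6.5-fold lower number from compound 3 to compound 4 (0.81 log units; beyond the scatter), so the direction of the change carries over from one core to the other, but its size does not: the same change on two cores in this assay, a 36-fold lower number (1.56 log units; beyond the scatter) from compound 1 to compound 2 and a 6.5-fold lower number (0.81 log units; beyond the scatter) from compound 3 to compound 4, 5.5-fold (0.74 log units) apart, beyond the scatter of two such steps

These two pairs show that the same change can give steps of different size in this series. They do not show whether the difference between the cores or the different place of the new group accounts for the gap, and they give no rule for any other core.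

The compounds shown leave open whether an amine or a longer chain such as ethoxy in that place would match methoxy. They also leave open how much the hydroxyl group shared by compound 3 and compound 4 contributes on its own.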